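This account rests on a few compounds, and the source may have more. Where it says the series, first, only, none or still open, it means among the compounds named here.

Among the compounds with values here, compound 3 `CCn1cnc2ncn([C@@H]3O[C@H](CO[Si](C)(C)C(C)(C)C)[C@@]4(OS(=O)(=O)C=C4N)[C@H]3O[Si](C)(C)C(C)(C)C)c2c1=O` is the only member of the set without a number: in a functional assay on MT4 cells (Homo sapiens) for cytotoxicity (on this read-out lower numbers stand for higher toxicity in this test and higher numbers for lower toxicity in this test), compound 3 reaches only the limit > 150000 nM, noted as the limit of > 150000 nM in this assay, at which 1 of the 3 values shown sits. Compound 1 `COc1ncnc2c1ncn2[C@@H]1O[C@H](CO[Si](C)(C)C(C)(C)C)[C@@]2(OS(=O)(=O)C=C2N)[C@H]1O[Si](C)(C)C(C)(C)C` gives 21000 nM and compound 2 `CC(C)(C)[Si](C)(C)OC[C@H]1O[C@@H](n2cnc3c(O)ncnc32)[C@H](O[Si](C)(C)C(C)(C)C)[C@]12OS(=O)(=O)C=C2N` gives 14000 nM in this assay; the two sit within the scatter of each other. Compound 4 `CC(C)(C)[Si](C)(C)OC[C@H]1O[C@@H](n2cnc3ccccc32)[C@H](O[Si](C)(C)C(C)(C)C)[C@]12OS(=O)(=O)C=C2N` differs from compound 3 by a group of 9 heavy atoms (7 carbon, 2 nitrogen; one five-membered aromatic ring with 2 hetero atoms, one six-membered aromatic ring of carbon only) in place of a group of 12 heavy atoms (7 carbon, 4 nitrogen, 1 oxygen; one five-membered aromatic ring with 2 hetero atoms, one six-membered aromatic ring with 2 hetero atoms), on a saturated ring carbon. Within the data shown here, the steps that bear on this position, an at least 7.1-fold higher number from compound 1 to compound 3 (0.85 log units; beyond the scatter) and an at least 10-fold higher number from compound 2 to compound 3 (1.02 log units; beyond the scatter), are both at least modest to large and both end at the limit. With compound 3 itself at the limit, the expected step of an at least 1.8-fold lower number from compound 3 to compound 4 (0.27 log units; that floor lies within the scatter) cannot be anchored tightly; compound 4 is expected to give about 80000 nM, within 20000 nM to 200000 nM in this assay.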

Compound 4, half-maximal cytotoxic concentration: 15000 nM
Beside the measured number, compound 4's estimate is 5.3-fold (0.73 log units) above it; measured number outside the range, below it.
By their numbers in this assay, from the lowest: compounds 2, 4 and 1 (each within the scatter of the next). At a limit, above all of these: compound 3.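

At this position on the saturated ring carbon, the 1H-benzimidazol-1-yl group reads the same as the groups it was compared with in this assay: a 1.1-fold higher number from compound 2 to compound 4 (0.03 log units; within the scatter), and a 1.4-fold lower number from compound 1 to compound 4 (0.15 log units; within the scatter). The only clear separation in the set lies with the group of compound 3, with an at least 10-fold lower number from compound 3 to compound 4 (1.00 log units; beyond the scatter). Compound 3 stays a limit and not a number: the limit of > 150000 nM in this assay, at which 1 of the 4 values shown sits.

As far as these compounds go, whether an amine on the six-membered aromatic ring would stay with compound 1, compound 2 and compound 4 or move toward compound 3 remains open. From the compounds shown here alone, the true size of any step to compound 3 also stays unknown.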